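Swapping the pendant aryl ring in a cytotoxicity series

The source may hold more compounds than are shown below. What is called first, only, known or untested is meant among the compounds shown, and "the series" means these compounds.

Compound 1, `Cc1ccccc1-c1cc(C)c(Nc2ccnc(Nc3ccc(C#N)cc3)n2)c(C)c1`, is a diarylpyrimidine-type molecule built around a shared core that carries a nitrile-bearing aniline on one side and a trisubstituted phenyl ring on the other. Among the compounds with values here, in an ADME assay on MT4 cells (Homo sapiens) for cytotoxicity, read by MTT assay, with a stated time of 4 days (a higher number here means that more compound is tolerated, a lower number that less compound is tolerated), compound 1 gives 3820 nM, which is the highest of the two numbers measured so far. Within the data shown here, its only measured neighbour is compound 2, `Cc1cc(-c2ccccc2F)cc(C)c1Nc1ccnc(Nc2ccc(C#N)cc2)n1`, where a fluoro stands in place of a methyl on an aromatic carbon; in this assay compound 2 gives 2120 nM, and the step of a 1.8-fold lower number from compound 1 to compound 2 (0.26 log units; within the scatter) stays within the scatter, so the two compounds cannot be ordered.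

Compound 3, `COc1ccc(-c2cc(C)c(Nc3ccnc(Nc4ccc(C#N)cc4)n3)c(C)c2)cc1`, differs from compound 1 by 4-methoxyphenyl in place of 2-methylphenyl on an aromatic carbon. Among the measured compounds shown here, no measured step changes this same group, so the only guidance is that the one step seen on the pendant ring did not move the number beyond the scatter. An unchanged result is therefore expected, with the step of a 1.2-fold lower number from compound 1 to compound 3 (0.08 log units; within the scatter) likely small. Compound 3 is estimated to give 3200 nM in this assay, within a range from 1200 nM to 8500 nM.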

Compound 3, half-maximal cytotoxic concentration: 2890 nM
For compound 3 the middle estimate is 1.1-fold (0.04 log units) above the measured one; the range from low to high includes it.
By their numbers in this assay, from the lowest: compounds 2, 3 and 1 (each within the scatter of the next).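

At this aromatic carbon, meta to two methyl groups, 4-methoxyphenyl takes the place of 2-methylphenyl with a 1.3-fold lower number from compound 1 to compound 3 (0.12 log units; within the scatter) and takes the place of 2-fluorophenyl with a 1.4-fold higher number from compound 2 to compound 3 (0.13 log units; within the scatter) in this assay and so the three compounds cannot be ordered. The earlier step compared only 2-methylphenyl with 2-fluorophenyl, whereas 4-methoxyphenyl has 8 heavy atoms against 7, brings an oxygen and a hydrogen-bond acceptor, and carries its substituent at a different place on the pendant ring, yet among these three compounds the number still stays within the scatter. Nothing measured here offers a cause for this, and none can be given.

Going by these compounds, all three groups at this carbon are substituted phenyl rings, so it remains open whether a group of another kind, such as an amine, a carboxylic acid or a longer alkyl chain, would also leave the number within the scatter. The same question stands for the rest of the molecule, since every compound shown keeps the nitrile-bearing aniline and the two methyl groups unchanged.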